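Hydroxycyclohexyl for Oxanyl on the Aniline Nitrogen

This account rests on a few compounds, and the source may have more. Where it says the series, first, only, none or still open, it means among the compounds named here.

Two measured compounds share one core and differ only in the group on the aniline nitrogen. Compound 1 `Clc1cc(-c2ccn3c(CC4CC4)nnc3c2Cl)ccc1NC1CC1` carries a cyclopropyl there, and in a functional assay on cells for positive allosteric modulation of metabotropic glutamate receptor 2 (Homo sapiens), read by scintillation counting and GTPgammaS binding, with a stated time of 30 min (on this read-out lower numbers stand for an effect already at smaller amounts and higher numbers for an effect only at larger amounts of compound), compound 1 gives 29.5 nM. Compound 2 `Clc1cc(-c2ccn3c(CC4CC4)nnc3c2Cl)ccc1NC1CCOCC1` carries an oxan-4-yl instead, and in this assay compound 2 gives 148 nM. The step of a 5.0-fold higher number from compound 1 to compound 2 (0.70 log units; beyond the scatter) is the only one available. Going by the values given here, compound 2 therefore stands at the higher of the two numbers, with compound 1 as its only neighbour.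

Compound 3 `O[C@H]1CC[C@H](Nc2ccc(-c3ccn4c(CC5CC5)nnc4c3Cl)cc2Cl)CC1` is not yet measured. Its difference from compound 2 is 4-hydroxycyclohexyl in place of oxan-4-yl on a nitrogen on an aromatic ring. Among the compounds with values here, the one known step concerns a ring of a different size entering at the same nitrogen, so it bears on this change only loosely: it shows that the group on this nitrogen matters, but not how a hydroxyl on a six-membered carbon ring will read. With a ring of the same size retained, the author expects a 1.2-fold lower number from compound 2 to compound 3 (0.09 log units; within the scatter), that is, no step beyond the scatter in this assay. For compound 3 the estimate in this assay is 120 nM, within 40 nM to 400 nM.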

Compound 3, half-maximal effective concentration: 33.1 nM
Compound 3: middle estimate off by 3.6-fold (0.56 log units), on the high side, and the stated range ends above it.
By their numbers in this assay, from the lowest: compounds 1 and 3 (each within the scatter of the next); then compound 2.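

In this assay there is a 4.5-fold lower number from compound 2 to compound 3 (0.65 log units; beyond the scatter) when 4-hydroxycyclohexyl replaces oxan-4-yl, so a six-membered non-aromatic ring on this nitrogen does not in itself go with the higher number of compound 2. Two rings of the same size, one with a ring oxygen and no hydrogen-bond donor and one of carbon only with a hydrogen-bond donor, read apart here. Against the cyclopropyl group there is only a 1.1-fold higher number from compound 1 to compound 3 (0.05 log units; within the scatter) and this lies within the scatter, so among the three groups shown on this nitrogen, the oxan-4-yl of compound 2 alone stands apart, while cyclopropyl and 4-hydroxycyclohexyl cannot be told apart on this read-out.

The compounds shown leave open whether a methoxy group or an amine in place of the hydroxyl of 4-hydroxycyclohexyl would read like compound 3 or like compound 2, and how the other stereoisomer of that group would read. Nothing available speaks to what lies behind the step from the oxan-4-yl to the 4-hydroxycyclohexyl group.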